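Two sulfonyl hydroxyguanidines and a chlorine added to each

This account rests on a few compounds, and the source may have more. Where it says the series, first, only, none or still open, it means among the compounds named here.

Compound 1 `Cc1ccc(S(=O)(=O)N/C(=N\O)Nc2ccc(Cl)cc2)cc1` is tested in a functional assay on COLO 205 cells (Homo sapiens) for cytotoxicity (a higher number here means a weaker inhibitor, a lower number a stronger inhibitor), where compound 1 gives 58 ug/mL, the highest number among the three measured compounds and beyond the scatter from the other two. Compound 2 `O=[N+]([O-])c1ccc(Oc2c(Cl)cc(S(=O)(=O)N/C(=N\O)Nc3ccc(Cl)cc3)cc2Cl)cc1` gives 12 ug/mL in this assay, and compound 3 `O=[N+]([O-])c1ccc(Oc2c(Cl)cc(S(=O)(=O)N/C(=N\O)Nc3ccc(Cl)cc3)cc2Cl)c(Cl)c1` gives 6 ug/mL. Between compounds 2 and 3 the change is chloro in place of hydrogen on an aromatic carbon, and it made a 2.0-fold lower number from compound 2 to compound 3 (0.30 log units; within the scatter). The difference between the core of compound 1 and the core of compound 2 is not broken down here. Compound 4 `Cc1ccc(S(=O)(=O)N/C(=N\O)Nc2ccc(Cl)c(Cl)c2)cc1` differs from compound 1 by chloro in place of hydrogen on an aromatic carbon, the same kind of change, but here ortho to a chloro group and meta to a large group rather than ortho to a large group and meta to a nitro group. Resting on the step from compound 2 to compound 3, a similar step a 1.5-fold lower number from compound 1 to compound 4 (0.18 log units; within the scatter) is expected in this assay for compound 4. Compound 4 is therefore estimated at 38 ug/mL, between 18 ug/mL and 85 ug/mL.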

Compound 4, half-maximal inhibitory concentration: 10 ug/mL
Estimate against measurement, compound 4: 3.8-fold (0.58 log units) above; measured number below the stated range.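

In this assay, chloro in place of hydrogen on an aromatic carbon gave a 5.8-fold lower number from compound 1 to compound 4 (0.76 log units; beyond the scatter). Set beside the earlier step, the size of this change did not carry over from one core to the other: the same change on two cores in this assay, a 2.0-fold lower number (0.30 log units; within the scatter) from compound 2 to compound 3 and a 5.8-fold lower number (0.76 log units; beyond the scatter) from compound 1 to compound 4, 2.9-fold (0.46 log units) apart, beyond the scatter of two such steps. These two pairs do not separate the effect of the core from that of the place of the chloro, which in compound 4 stands ortho to a chloro group, and they set no rule for the wider series.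

On these data alone, it remains open whether an amine, a methoxy or a fluoro in that place would lower the number as far as chloro does in compound 4. As far as these compounds go, it also remains open what chloro in that same place would do on the core of compound 2.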